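Swapping Fluoro for Methoxy: What Cytotoxicity to Expect

The source may hold more compounds than are shown below. What is called first, only, known or untested is meant among the compounds shown, and "the series" means these compounds.

Compound 1, `Fc1ccc(-c2nn3c(NC4CCCC4)cccc3c2-c2ccnc(NC3CCCC3)n2)cc1`, was tested in an ADME assay on Vero cells (Chlorocebus sabaeus) for cytotoxicity; on this read-out higher numbers stand for lower toxicity in this test and lower numbers for higher toxicity in this test. In this assay compound 1 reaches only a limit, > 160000 nM. Two related compounds built on a different shared core give some context. Compound 2, `Oc1ccc(-c2nn3c(NC4CCCC4)nccc3c2-c2ccnc(NC3CCCC3)n2)cc1`, gives 27000 nM in this assay. Compound 3, `CCCOc1ccc(-c2nn3c(NC4CCCC4)nccc3c2-c2ccnc(NC3CCCC3)n2)cc1`, differs from compound 2 by a propyl in place of hydrogen on an oxygen; for compound 3 this assay reports only a limit, > 20000 nM. The step that the limit leaves unreadable from compound 2 to compound 3 therefore has no readable size, and only the two values themselves can be stated. Compound 4, `COc1ccc(-c2nn3c(NC4CCCC4)cccc3c2-c2ccnc(NC3CCCC3)n2)cc1`, is the compound still to be measured; it differs from compound 1 by methoxy in place of fluoro on an aromatic carbon. Among the compounds with values here, no measured step matches this change exactly, and the two limits, the limit of > 160000 nM in this assay, at which 1 of the 3 values shown sits, and (the limit of > 20000 nM in this assay, at which 1 of the 3 values shown sits), show how often compounds of this kind sit where the test stops counting, which makes any step from compound 1 hard to read. The expected step from compound 1 to compound 4 is an at least 1.6-fold lower number from compound 1 to compound 4 (0.20 log units; that floor lies within the scatter), which is not readable beyond the scatter given where compound 1 stands. For compound 4 the estimate is 100000 nM, with a range from 30000 nM to 300000 nM.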

Compound 4, half-maximal cytotoxic concentration: > 100000 nM
Compound 4 ended at the assay's limit; the forecaster's own chance of this, stated with the estimate: 60%; the middle value sits exactly at the limit.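

Within the data shown here, compound 1 and compound 4 each reach only a limit in this assay, and no step between them can be read. The compounds shown leave open whether 4-fluorophenyl and 4-methoxyphenyl on the shared core differ at all on this read-out, and at what concentration either compound would reach the half-maximal cytotoxic point.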